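Removing the Iodine from Compound 3

The compounds below may be only part of what the source reports. "The series", "measured", "known", "first", "only" and "open" are said of these compounds alone.

Compound 1 `CCCCCCC(=O)C(Br)=C(Br)Br`: > 20 ug/mL, a limit of the assay.
Compound 2 `CCC[C@@H](O)C1=C(Br)/C(=C/I)OC1=O`: < 0.1 ug/mL, a limit of the assay.
Compound 3 `CCC[C@@H](OC(C)=O)C1=C(Br)[C@@](CI)(OC)OC1=O`: 12.9 ug/mL.

In a functional assay on LNCaP cells (Homo sapiens) for cytotoxicity (on this read-out lower numbers stand for an effect already at smaller amounts and higher numbers for an effect only at larger amounts of compound), compound 3 is the only one of the three to give a number; the other two sit at limits, one at the limit of < 0.1 ug/mL in this assay, at which 1 of the 3 values shown sits, and one at the limit of > 20 ug/mL in this assay, at which 1 of the 3 values shown sits. Compound 4 `CCC[C@@H](OC(C)=O)C1=C(Br)[C@@](C)(OC)OC1=O` differs from compound 3 by hydrogen in place of iodo on a saturated chain carbon bound to a saturated ring carbon. Going by the values given here, a single small change of this kind, with no other pair of measured compounds to compare it against, is expected to stay within the scatter, with the step from compound 3 to compound 4 estimated as a 1.2-fold higher number from compound 3 to compound 4 (0.07 log units; within the scatter). Compound 4 is therefore expected to give about 15 ug/mL, within 6 ug/mL to 35 ug/mL.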

Compound 4, concentration for half-maximal effect: 1.7 ug/mL
Compound 4: middle estimate off by 8.8-fold (0.95 log units), on the high side; the measured number lies below the stated range.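

In this assay, hydrogen in place of iodo on a saturated chain carbon bound to a saturated ring carbon gives a 7.6-fold lower number from compound 3 to compound 4 (0.88 log units; beyond the scatter). Going by these compounds alone, this is the first step that can be read between two compounds differing in one place, and it shows that going from iodomethyl to methyl does not lose the effect but brings it to smaller amounts. Nothing measured here gives a cause for the step. This one pair is all that speaks to this place. From the compounds shown here alone, how a chloromethyl or hydroxymethyl group would read there stays open, as does whether the step holds with the free hydroxyl in place of the acetate.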